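This account rests on a few compounds, and the source may have more. Where it says the series, first, only, none or still open, it means among the compounds named here.

Measured so far:
Compound 1, `COC1CN(C(=O)/C=C/c2ccncc2-c2ccc3ccccc3c2)C1`: in an assay on a protein complex for inhibition of CDK8/Cyclin C (Homo sapiens), with a stated time of 1 h, tested at 10 uM (on this read-out lower numbers stand for less inhibition and higher numbers for more inhibition at the one concentration tested (going by the name of the read-out)), compound 1 gives 100%.
Compound 2, `O=C(O)CCNC(=O)/C=C/c1ccncc1-c1ccc2ccccc2c1`: in this assay compound 2 gives 91%.

Within the data shown here, compound 2 holds the lower of the two numbers, but its only neighbour is compound 1, and the step of a number 9 percentage points lower from compound 1 to compound 2 (within the scatter) lies within the scatter, so the two cannot be told apart on these numbers. Compound 3 is `CC(C)[C@@H](NC(=O)/C=C/c1ccncc1-c1ccc2ccccc2c1)C(=O)O`. Its difference from compound 2 is 1-carboxy-2-methylpropyl in place of 2-carboxyethyl on an amide-type nitrogen. Among the measured compounds shown here, only one measured step is at hand, and it does not concern the same place: a number 9 percentage points lower from compound 1 to compound 2 (within the scatter) exchanged the whole group on the carbonyl carbon, whereas the change to compound 3 keeps the amide-type nitrogen and its carboxyalkyl chain and only lengthens that chain by two carbon atoms with a defined stereocentre. That one step was within the scatter even though the exchanged groups differed in kind; it gives no reason to expect a shift beyond the scatter here, though the evidence is thin. The number for compound 3 is therefore expected to stay roughly level with that of compound 2, the expected step being a number 3 percentage points lower from compound 2 to compound 3 (within the scatter). The estimate for compound 3 in this assay is 88%, within 68% to 100%.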

Compound 3, a percentage reported as inhibition, at one concentration (the size of the read-out at that concentration, not a potency): 77%
Compound 3: middle estimate off by 11 percentage points, on the high side, within the range that was stated.
By their numbers in this assay, from the lowest: compound 3; then compounds 2 and 1 (each within the scatter of the next).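

In this assay the amide-type nitrogen proves to be a place where a change in the carboxyalkyl group can be read: 1-carboxy-2-methylpropyl in place of 2-carboxyethyl gives a number 14 percentage points lower from compound 2 to compound 3 (beyond the scatter) and thus separates two compounds that both carry a carboxylic acid. The earlier exchange of the whole group on the carbonyl carbon, a number 9 percentage points lower from compound 1 to compound 2 (within the scatter), had separated nothing, whereas (1-carboxy-2-methylpropyl)amino in place of 3-methoxyazetidin-1-yl gives a number 23 percentage points lower from compound 1 to compound 3 (beyond the scatter), so the same kind of exchange can be read once this group enters. No measurement at hand offers an explanation for this step.

The entering group differs from the one it replaces both in its carbon count and in its defined stereocentre, and the compounds shown do not tell these two differences apart. On these data alone, it stays open how a 1-carboxyethyl group or the opposite stereocentre of 1-carboxy-2-methylpropyl would read at this nitrogen, and whether a methyl ester or a primary amide in place of the carboxylic acid would keep the number of compound 3.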